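Trimming an isopropyl to methyl on a fused core

This account rests on a few compounds, and the source may have more. Where it says the series, first, only, none or still open, it means among the compounds named here.

Three compounds carry a shared cyclohexyl diamine side chain on different fused cores, and each has been measured in a physicochemical assay for lipophilicity, using the shake flask method, at pH 7.4; on this read-out lower numbers stand for lower lipophilicity and higher numbers for higher lipophilicity. Compound 1 `CC(C)c1ccn2ncnc(N[C@H]3CC[C@H](N(C)C)CC3)c12` gives 1.3 in this assay, the highest of the three numbers. Compound 2 `CN(C)[C@H]1CC[C@H](Nc2ncnc3cscc23)CC1` gives 0.3 in this assay, and compound 3 `CN(C)[C@H]1CC[C@H](Nc2ncnc3ccsc23)CC1` gives -0.2 in this assay; both lie below compound 1 by more than the usual scatter, compound 3 the furthest away.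

The step under consideration leads from compound 1 to compound 4 `Cc1ccn2ncnc(N[C@H]3CC[C@H](N(C)C)CC3)c12`, which has not yet been measured in this assay. The change is methyl in place of isopropyl on an aromatic carbon. Among the compounds with values here, no pair of measured compounds in this set shares exactly this change, so there is no measured step of this kind to lean on. Because compound 1 starts from 1.3, and the change removes two of the three carbons of the isopropyl group, the step is expected to be a drop of moderate size, beyond the scatter, with an expected step of a number 0.80 log units lower from compound 1 to compound 4 (beyond the scatter). Compound 4 is therefore estimated to give 0.5 in this assay, within a range from -0.1 to 1.1.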

Compound 4, distribution coefficient: 0.2
For compound 4 the middle estimate is 0.30 log units above the measured one; measured number inside the range.
By their numbers in this assay, from the lowest: compound 3; then compounds 4 and 2 (each within the scatter of the next); then compound 1.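

In this assay, the change from isopropyl to methyl on this aromatic carbon of the five-membered ring gives a number 1.10 log units lower from compound 1 to compound 4 (beyond the scatter), a large step. Within the data shown here, this is the first measured step at this position: the earlier compounds differ from one another in their cores, so none of them could isolate a change in this substituent, and the result shows that the read-out responds strongly to it on the core of compound 1. Nothing shown here explains the size of the step.

The compounds shown leave open whether an ethyl group at this carbon would land partway along this step or whether most of the drop comes with a smaller trim. They also leave open how a group carrying oxygen or nitrogen, such as methoxy or an amine, would read at the same place.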